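The source may hold more compounds than are shown below. What is called first, only, known or untested is meant among the compounds shown, and "the series" means these compounds.

Compound 1 `Cc1ccc(S(=O)(=O)c2cnc3cc(F)ccc3c2N2CCC(C)CC2)cc1C` gives 90% in an assay on isolated protein for displacement of a labelled ligand from metabotropic glutamate receptor 5 (Homo sapiens), with a stated time of 60 min, tested at 1 uM; on this read-out higher numbers stand for more inhibition at the one concentration tested (going by the name of the read-out) and lower numbers for less inhibition.
Compound 2 `CC1CCN(c2c(S(=O)(=O)c3ccc(F)cc3)cnc3ccc(Cl)cc23)CC1` gives 89% in this assay.
Compound 3 `CC1CCN(c2c(S(=O)(=O)c3ccccc3)cnc3cc(Cl)ccc23)CC1` gives 93% in this assay.

Among these three numbers compound 1 stands second highest. Its nearest neighbour is compound 2 and its furthest is compound 3, yet both gaps lie within the usual scatter of repeated measurements, so the three compounds cannot be ranked against each other on this evidence. Within the data shown here, no single-point step between measured compounds is available: compounds 2 and 3 differ from compound 1 in more than one place at once, and what they show is only that several variations of this shared core give numbers close to one another.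

The unmeasured compound 4 `CC1CCN(c2c(S(=O)(=O)c3ccc(Cl)cc3)cnc3cc(F)ccc23)CC1` is reached from compound 1 by one change, (4-chlorophenyl in place of 3,4-dimethylphenyl on a sulfonyl sulfur). Since compounds 2 and 3, which each carry a different group on the sulfonyl sulfur, sit within the scatter of compound 1, no step beyond the scatter is expected here either: the estimated step of a number 2 percentage points lower from compound 1 to compound 4 (within the scatter) is a small one, if anything slightly downward. Compound 4 is therefore expected to give about 88% in this assay, with a likely range from 75% to 96%.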

Compound 4, a percentage reported as inhibition, at one concentration (the size of the read-out at that concentration, not a potency): 90%
For compound 4 the middle estimate is 2 percentage points below the measured one; the measured number falls inside the stated range.
By their numbers in this assay, from the lowest: compounds 2, 1, 4 and 3 (each within the scatter of the next).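

On the sulfonyl sulfur, 4-chlorophenyl in place of 3,4-dimethylphenyl gives no change at the digits printed from compound 1 to compound 4 (within the scatter) in this assay. This step isolates this one place, whereas compounds 2 and 3 each differ from compound 1 in more than one place and could only suggest that the group on the sulfonyl sulfur might be varied without a step beyond the scatter; here a chlorine-bearing six-membered aromatic ring takes the place of a dimethyl-bearing one, with no hydrogen-bond donors or acceptors entering or leaving, and the read-out stays within the scatter. No supporting measurement is available that could say why this exchange leaves the number where it is.

On these data alone, the two groups compared here are both aromatic rings of carbon only, so it stays open whether the same holds for a group of another kind on the sulfonyl sulfur, such as a cyclohexyl ring, a pyridine ring or a phenyl ring bearing a carboxylic acid or an amine. As far as these compounds go, a percentage at one concentration is also not a potency, so it remains open whether compound 1 and compound 4 would still match across a full concentration series.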